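The source may report more compounds than this note shows. Statements on the series, on what has been measured and on what is new or still open speak of the compounds shown alone.

In a functional assay on MCF7 cells (Homo sapiens) for inhibition, read by MTT assay, with a stated time of 48 h (on this read-out higher numbers stand for weaker inhibition and lower numbers for stronger inhibition), compound 1 `CCOC(=O)C1=C(N/C=N/c2ncc(-c3ccccc3)s2)Nc2[nH]nc(C)c2C1c1ccc(N(C)C)cc1` gives 10100 nM and compound 3 `CCOC(=O)C1=C(N/N=C(\C#N)C(N)=O)Nc2[nH]nc(C)c2C1c1ccc(N(C)C)cc1` gives 50100 nM, the higher of the two numbers, with compound 1 lower beyond the scatter. For compound 2 `CCOC(=O)C1=C(N/N=C(\c2ccc([N+](=O)[O-])cc2)N2CCN(c3ccc(F)cc3)CC2)Nc2[nH]nc(C)c2C1c1ccc(N(C)C)cc1` the assay reports only a limit, > 100000 nM, and not a number. Compound 4 `CCOC(=O)C1=C(N)Nc2[nH]nc(C)c2C1c1ccc(N(C)C)cc1` differs from compound 3 in one place: a hydrogen atom in place of a group of 7 heavy atoms (3 carbon, 3 nitrogen, 1 oxygen; no ring), on an amine nitrogen. Among the compounds with values here, no measured pair shows a comparable change, so the direction of this step is uncertain; it is expected to be small, at most a modest shift towards weaker inhibition or none beyond the scatter, as a 1.2-fold higher number from compound 3 to compound 4 (0.08 log units; within the scatter). In this assay compound 4 is therefore estimated at 60000 nM, within a range from 15000 nM to 200000 nM.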

Compound 4, half-maximal inhibitory concentration: 5060 nM
For compound 4 the middle estimate is 12-fold (1.07 log units) above the measured one; measured number below the stated range.
By their numbers in this assay, from the lowest: compounds 4 and 1 (each within the scatter of the next); then compound 3. At a limit, above all of these: compound 2.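

Replacing the group of 7 heavy atoms on the amine nitrogen with a hydrogen atom gives a 9.9-fold lower number from compound 3 to compound 4 (1.00 log units; beyond the scatter) in this assay and shows that this position matters for the read-out. Compound 4 also shows that inhibition at this level needs no substituent on this nitrogen. Nothing measured here accounts for the step.

On these data alone, whether a small group on this nitrogen, such as methyl or acetyl, would keep the number of compound 4 remains open. So does the effect of a longer chain there.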